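The source may hold more compounds than are shown below. What is called first, only, known or untested is meant among the compounds shown, and "the series" means these compounds.

Compound 1 `COc1cc2c(Oc3ccc(NC(=O)c4nn(-c5ccccc5)c(=O)c5ccccc45)cc3F)ccnc2cc1OCCCN1CCCC1` in a functional assay on MKN-45 cells (Homo sapiens) for cytotoxicity, read by MTT assay, with a stated time of 72 h (a lower number here means a stronger inhibitor, a higher number a weaker inhibitor), gives 530 nM.
Compound 2 `COc1cc2c(Oc3ccc(NC(=O)c4nn(-c5cccc(F)c5)c(=O)c5ccccc45)cc3F)ccnc2cc1OCCCN1CCCC1` in this assay gives 160 nM.
Compound 3 `COc1cc2c(Oc3ccc(NC(=O)c4nn(-c5ccccc5)c(=O)c5ccccc45)cc3F)ccnc2cc1OCCCN1CCCCC1` in this assay gives 590 nM.

Compound 2 differs from compound 1 by fluoro in place of hydrogen on an aromatic carbon, and this change gave a 3.3-fold lower number from compound 1 to compound 2 (0.52 log units; beyond the scatter). Compound 3 differs from compound 1 in the core by piperidin-1-yl in place of pyrrolidin-1-yl on a saturated chain carbon, three bonds along the chain from an oxygen on an aromatic ring, which gave a 1.1-fold higher number from compound 1 to compound 3 (0.05 log units; within the scatter), so the two cores behave alike in this assay. Compound 4 `COc1cc2c(Oc3ccc(NC(=O)c4nn(-c5ccccc5F)c(=O)c5ccccc45)cc3F)ccnc2cc1OCCCN1CCCCC1` is not yet measured; it differs from compound 3 by fluoro in place of hydrogen on an aromatic carbon. Among the measured compounds shown here, this is the same kind of change as the one from compound 1 to compound 2, but not the same: there the fluoro sits meta to a large group, here it sits ortho to a large group. The expectation for compound 4 in this assay therefore rests on the modest gain seen in a 3.3-fold lower number from compound 1 to compound 2 (0.52 log units; beyond the scatter), tempered because a 1.1-fold higher number from compound 1 to compound 3 (0.05 log units; within the scatter) shows the core itself changes little, and because the place of the fluoro is not the same. Compound 4 is expected to give a step of a 1.8-fold lower number from compound 3 to compound 4 (0.27 log units; within the scatter) from compound 3, smaller than the earlier one. Compound 4 is estimated at 320 nM, expected to fall between 130 nM and 750 nM.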

Compound 4, half-maximal inhibitory concentration: 350 nM
Compound 4: the middle estimate sits 1.1-fold (0.04 log units) below what was measured; measured number inside the range.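

In this assay, phenyl to 2-fluorophenyl on the core of compound 3 gave a 1.7-fold lower number from compound 3 to compound 4 (0.23 log units; within the scatter), and the gap between this step and the earlier one does not exceed what repeated measurements would produce: the same change on two cores in this assay, a 3.3-fold lower number (0.52 log units; beyond the scatter) from compound 1 to compound 2 and a 1.7-fold lower number (0.23 log units; within the scatter) from compound 3 to compound 4, 2.0-fold (0.29 log units) apart, within the scatter of two such steps. The two steps are therefore compatible with the change carrying over from the core of compound 1 to the core of compound 3, but they do not prove it, as the new step cannot on its own be told apart from scatter. Nor is this a clean test of transfer: in compound 4 the fluoro is ortho to a large group, whereas in compound 2 it stands at another place on the ring, so the core and the place of the fluoro differ together.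

The compounds shown leave open how the two fluoro places would compare on a single core. They also leave open whether chloro or methoxy on this ring, or a morpholine or a longer chain at the other end of the molecule, would behave in the same way.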